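Benzyl for acetyl on the amine nitrogen

The compounds below may be only part of what the source reports. "The series", "measured", "known", "first", "only" and "open" are said of these compounds alone.

Of the compounds shown here, three have been measured in an assay for inhibition of apolipoprotein B-100 (Homo sapiens), tested at 100 nM; on this read-out higher numbers stand for weaker inhibition and lower numbers for stronger inhibition. Compound 1 `COC(=O)N[C@H]1Cc2ccc(NC(=O)c3cc(C)ccc3-c3ccc(C(F)(F)F)cc3)cc2C1` gives 2.2 nM and compound 2 `Cc1ccc(-c2c(C)cccc2C(=O)Nc2ccc3c(c2)CC(NS(=O)(=O)c2ccccc2)C3)cc1` gives 2.5 nM. Compound 3 `CC(=O)NC1Cc2ccc(NC(=O)c3ccccc3-c3ccc(C(F)(F)F)cc3)cc2C1` gives 120 nM, the highest of the three numbers; the gap to compound 2 and the gap to compound 1 both lie well beyond the scatter. For the measured compounds named here, no two measured compounds differ in a single place, so no measured step is available.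

Compound 4 `O=C(Nc1ccc2c(c1)CC(NCc1ccccc1)C2)c1ccccc1-c1ccc(C(F)(F)F)cc1` differs from compound 3 in one respect: benzyl in place of acetyl on an amine nitrogen. Both compound 1 and compound 2 carry a group other than acetyl on that amine nitrogen and sit far below compound 3, but neither is a single-point change from it, so these numbers only hint at the direction. From compound 3 to compound 4 a moderate decrease is expected, a 2.4-fold lower number from compound 3 to compound 4 (0.38 log units; beyond the scatter), with considerable uncertainty on either side. For compound 4 the estimate in this assay is 50 nM, within a range of 8 nM to 400 nM.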

Compound 4, half-maximal inhibitory concentration: 340 nM
Estimate against measurement, compound 4: 6.8-fold (0.83 log units) below; the measured number falls inside the stated range.
By their numbers in this assay, from the lowest: compounds 1 and 2 (each within the scatter of the next); then compound 3; then compound 4.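

For the compounds shown here, this is the first single-place step: in this assay, benzyl in place of acetyl on the amine nitrogen gives a 2.8-fold higher number from compound 3 to compound 4 (0.45 log units; beyond the scatter), so the group at this position does affect the read-out, and here the larger group comes with the weaker result. The swap removes the carbonyl and introduces an aromatic ring in one move, so this step cannot assign the shift to either alteration alone. No measurement at hand accounts for the step.

A benzoyl group on the same nitrogen would keep the carbonyl and carry the aromatic ring, and would begin to separate the two alterations. From the compounds shown here alone, the free amine and a small alkyl group such as ethyl also remain open, as either would show how this position responds without a carbonyl or an aromatic ring.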